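The compounds below may be only part of what the source reports. "The series", "measured", "known", "first", "only" and "open" are said of these compounds alone.

Measured compounds:
compound 1 `O=C(/C=C\Nc1ccc(F)cc1)c1cn(-c2ccccc2)nc1-c1ccccc1`, in a functional assay on U-87MG ATCC cells (Homo sapiens) for antiproliferative activity, read by MTT assay, with a stated time of 48 h (a higher number here means a weaker inhibitor, a lower number a stronger inhibitor), compound 1 gives 10200 nM
compound 2 `O=C(/C=C\Nc1ccc(Cl)cc1)c1cn(-c2ccccc2)nc1-c1ccccc1`, in this assay compound 2 gives 11400 nM

Among the measured compounds shown here, compound 2 holds the higher of the two numbers so far, but only just: the step of a 1.1-fold higher number from compound 1 to compound 2 (0.05 log units; within the scatter) keeps compound 1 and compound 2 within the scatter of each other, so the two cannot be told apart on these data. The change that leads from compound 2 to compound 3 `O=C(/C=C\Nc1ccc(C(F)(F)F)cc1)c1cn(-c2ccccc2)nc1-c1ccccc1` is trifluoromethyl in place of chloro on an aromatic carbon. For the measured compounds named here, the one measured step that bears on it is the exchange of one halogen for another at the same position, a 1.1-fold higher number from compound 1 to compound 2 (0.05 log units; within the scatter), which left the number essentially where it was. With nothing else to go on, a similar outcome is expected here: the step of a 1.1-fold higher number from compound 2 to compound 3 (0.02 log units; within the scatter) is estimated to stay within the scatter, with no clear direction. Compound 3 is therefore expected to give about 12000 nM in this assay, with a range from 6000 nM to 25000 nM that allows for the usual spread of such measurements.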

Compound 3, half-maximal inhibitory concentration: > 50000 nM
Compound 3 gave a limit, no number (the forecaster's own chance of this, stated with the estimate: 10%); at least 4.1-fold (0.61 log units) between middle value and limit.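

In this assay compound 3 stands at a limit of the assay and not at a number: the limit of > 50000 nM in this assay, at which 1 of the 3 values shown sits. The earlier compounds shown here suggested that this place, on an aromatic carbon para to a large group, tolerated exchange, since fluoro and chloro could not be told apart there, with a 1.1-fold higher number from compound 1 to compound 2 (0.05 log units; within the scatter); trifluoromethyl shows that the place is not indifferent to what it carries, with an at least 4.3-fold higher number from compound 2 to compound 3 (0.64 log units; beyond the scatter) and with an at least 4.9-fold higher number from compound 1 to compound 3 (0.69 log units; beyond the scatter). The 4-chlorophenyl to 4-(trifluoromethyl)phenyl change therefore weakens the compound clearly, although the full size of the loss cannot be read from a limit.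

The compounds shown leave open whether an amine, a methoxy group, a carboxylic acid or a plain hydrogen at this place would stay with fluoro and chloro or fall with trifluoromethyl. They also offer no measurement that ties the loss to any property of trifluoromethyl, and they leave open whether the same exchange elsewhere on the shared core would have a similar outcome.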